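This account rests on a few compounds, and the source may have more. Where it says the series, first, only, none or still open, it means among the compounds named here.

Of the compounds shown here, three built on one shared core have been tested in a functional assay on CWR22R cells (Homo sapiens) for inhibition; a higher number here means a weaker inhibitor, a lower number a stronger inhibitor. Compound 1, `CCn1c(=O)/c(=C2\Sc3ccc(C)cc3N2C)s/c1=C\c1ccncc1Nc1ccccc1F`, gives 150 nM in this assay, the lowest of the three numbers. Compound 3, `CCn1c(=O)/c(=C2\Sc3cc(F)ccc3N2C)s/c1=C\c1ccncc1Nc1ccccc1Cl`, gives 490 nM, and compound 2, `CCn1c(=O)/c(=C2\Sc3ccccc3N2C)s/c1=C\c1ccncc1Nc1cc(C)ccc1C`, gives 1800 nM. Among the measured compounds shown here, both differ from compound 1 in more than one place, so neither comparison isolates a single change, and no pair of measured compounds that differ in one place is available.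

Compound 4, `CCn1c(=O)/c(=C2\Sc3ccc(C)cc3N2C)s/c1=C\c1ccncc1Nc1ccccc1Cl`, has not yet been measured. It differs from compound 1 in one place: chloro in place of fluoro on an aromatic carbon. Compound 3 also carries a (2-chlorophenyl)amino group and gives the higher number 490 nM, but it differs from compound 1 elsewhere as well, so what the chloro alone does cannot be read from these data. A small step is expected, toward a somewhat higher number, of a size that may not exceed the scatter. The estimate for compound 4 is 240 nM, with a range from 100 nM to 600 nM, which is expected to mean a step of a 1.6-fold higher number from compound 1 to compound 4 (0.20 log units; within the scatter).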

Compound 4, half-maximal inhibitory concentration: 350 nM
Estimate against measurement, compound 4: 1.5-fold (0.16 log units) below, and the stated range covers the measured number.
By their numbers in this assay, from the lowest: compound 1; then compounds 4 and 3 (each within the scatter of the next); then compound 2.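

In this assay, going from (2-fluorophenyl)amino to (2-chlorophenyl)amino gives a 2.3-fold higher number from compound 1 to compound 4 (0.37 log units; beyond the scatter), the first step among these compounds that isolates a single change. It shows that this position, on an aromatic carbon ortho to a large group, is sensitive to which halogen it carries: with the rest of the molecule unchanged, the number moves modestly but beyond the scatter, and fluoro gives the stronger inhibitor of this pair. Nothing available explains why the two halogens differ.

As far as these compounds go, this is a single pair on a single version of the core, so it remains open whether the same step would appear with other groups elsewhere on the molecule. Also open, from the compounds shown here alone, is how hydrogen, methoxy or a nitrile at this position would compare with fluoro and chloro.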